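Dropping one methoxy group: what a small step predicts

The compounds below may be only part of what the source reports. "The series", "measured", "known", "first", "only" and "open" are said of these compounds alone.

Compound 1, `COc1cc(-c2cc(/C=C/C(=O)c3ccc(N)cc3)[nH]n2)cc(OC)c1OC`, gives -40% in a functional assay on RPMI-8226 cells (Homo sapiens) for cytotoxicity, read by sulforhodamine B assay, with a stated time of 48 h, tested at 100 uM; a lower number here means a stronger effect, a higher number a weaker effect of the compound at the concentration tested.
Compound 2, `COc1ccc(C(=O)/C=C/c2cc(-c3cc(OC)c(OC)c(OC)c3)n[nH]2)cc1OC`, gives -41% in this assay.
Compound 3, `COc1ccc(C(=O)/C=C/c2cc(-c3cc(OC)c(OC)c(OC)c3)n[nH]2)cc1`, gives -34% in this assay.

The three measured compounds share a core and differ in the group on the carbonyl carbon: 4-aminophenyl in place of 3,4-dimethoxyphenyl on a carbonyl carbon. Their values lie close together: a number 1 percentage points lower from compound 1 to compound 2 (within the scatter), a number 6 percentage points higher from compound 1 to compound 3 (within the scatter). Compound 4, `COc1ccc(-c2cc(/C=C/C(=O)c3ccc(N)cc3)[nH]n2)cc1OC`, is not yet measured. It comes from compound 1 by hydrogen in place of methoxy on an aromatic carbon. The same kind of change is already measured once, from compound 2 to compound 3 as hydrogen in place of methoxy on an aromatic carbon, where the step was a number 7 percentage points higher from compound 2 to compound 3 (within the scatter). The surroundings differ slightly: in compound 1 the leaving methoxy is also meta to a methoxy group, which is not so in compound 2. On the basis of that earlier step, compound 4 is expected to show a step of a number 7 percentage points higher from compound 1 to compound 4 (within the scatter) relative to compound 1, staying within the scatter. Compound 4 is therefore estimated at -33%, between -55% and -10%.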

Compound 4, a percentage reported as activity, at one concentration (the size of the read-out at that concentration, not a potency): -40%
Estimate against measurement, compound 4: 7 percentage points above; measured number inside the range.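

In this assay, hydrogen in place of methoxy on an aromatic carbon gave no change at the digits printed from compound 1 to compound 4 (within the scatter). Set beside the earlier case, the change reads alike on the two cores: the same change on two cores in this assay, a number 7 percentage points higher (within the scatter) from compound 2 to compound 3 and no change at the digits printed (within the scatter) from compound 1 to compound 4, 7 percentage points apart, within the scatter of two such steps This shows that the methoxy group could be lost on either core without a step beyond the scatter, but two pairs, both with steps inside the scatter, do not show that the same would hold on any other core.

The compounds shown leave open whether a hydroxy or ethoxy group in that place, or a carboxylic acid in place of the amino group, would move the read-out beyond the scatter. As far as these compounds go, the read-out gives the size of the effect at one concentration only; whether the effect would be stronger or weaker at other concentrations also stays open.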